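Adding a further methoxy to compound 2

This account rests on a few compounds, and the source may have more. Where it says the series, first, only, none or still open, it means among the compounds named here.

Measured so far in a functional assay on HeLa cells (Homo sapiens) for inhibition, read by MTT assay, with a stated time of 48 h (a lower number here means a stronger inhibitor of growth, a higher number a weaker inhibitor of growth), on the shared core:
compound 1 (`COc1ccc(C2=NN(C(=O)c3cccnc3)C(c3cn(C)c4ccc(Br)cc34)C2)cc1`) gives 890 nM as its value
compound 2 (`COc1ccc(C2=NN(C(=O)c3cccnc3)C(c3cn(C)c4ccc(Br)cc34)C2)cc1OC`) gives 2090 nM as its value

Of these two, compound 2 holds the higher number, at 2090 nM in this assay and so is the weaker inhibitor of growth. Compound 3 (`COc1cc(C2=NN(C(=O)c3cccnc3)C(c3cn(C)c4ccc(Br)cc34)C2)cc(OC)c1OC`) differs from it by one change, methoxy in place of hydrogen on an aromatic carbon which turns 3,4-dimethoxyphenyl into 3,4,5-trimethoxyphenyl. Among the measured compounds shown here, only one measured step is of the same kind, methoxy in place of hydrogen on an aromatic carbon. That step is a 2.3-fold higher number from compound 1 to compound 2 (0.37 log units; beyond the scatter) and it is modest. A single step is thin evidence, so a modest further rise is expected, though a result within the scatter would not surprise. The expected change is a 1.4-fold higher number from compound 2 to compound 3 (0.16 log units; within the scatter) in this direction. Compound 3 is estimated at 3000 nM with an expected range from 1100 nM to 8000 nM on this read-out.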

Compound 3, concentration for 50% growth inhibition: > 10000 nM
Compound 3 ended at the assay's limit; the forecaster's own chance of this, stated with the estimate: 3%; at least 3.3-fold (0.52 log units) between middle value and limit.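

Compound 3 stands at a limit of the assay, not at a number: the limit of > 10000 nM in this assay, at which 1 of the 3 values shown sits. In this assay, the methoxy entering ortho to a methoxy group and meta to a large group gives an at least 4.7-fold higher number from compound 2 to compound 3 (0.67 log units; beyond the scatter), so the upward direction of the earlier step holds at this new place on the ring. Taken as one change, 3,4,5-trimethoxyphenyl in place of 4-methoxyphenyl gives an at least 11-fold higher number from compound 1 to compound 3 (1.05 log units; beyond the scatter), a large loss of growth inhibition that the modest earlier step did not reveal.

On these data alone, how far compound 3 lies past the limit remains unknown, so both steps have only a lower bound. Also open, as far as these compounds go, is whether the loss follows the count of methoxy groups or this one place, and how a hydroxyl, a fluorine or an amine on the same aromatic carbon would read.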